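The source may report more compounds than this note shows. Statements on the series, on what has been measured and on what is new or still open speak of the compounds shown alone.

Measured compounds:
compound 1 `Cc1ccc(S(=O)(=O)Cc2ccccc2)cc1C#Cc1cc(Cl)ccc1OCC(=O)O` — 5 nM
compound 2 `CS(=O)(=O)c1ccc(F)c(C#Cc2cc(Cl)ccc2OCC(=O)O)c1` — 3.3 nM
compound 3 `O=C(O)COc1ccc(Cl)cc1C#Cc1cc(CO)ccc1F` — 73 nM

In an assay on CHO cells for displacement of a labelled ligand from prostaglandin D2 receptor 2 (Homo sapiens), read by scintillation counting (on this read-out lower numbers stand for stronger inhibition and higher numbers for weaker inhibition), compound 1 gives 5 nM, the second highest of the three numbers. Compound 2 gives 3.3 nM, which sits within the scatter of compound 1, so the two cannot be ordered. Compound 3 gives 73 nM, clearly beyond the scatter from both.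

Going by the values given here, the only single-point step measured so far is a 22-fold higher number from compound 2 to compound 3 (1.34 log units; beyond the scatter), a hydroxymethyl in place of methylsulfonyl on an aromatic carbon. It shows that removing the sulfonyl-bearing group from this position costs a great deal.

Compound 4 `CNS(=O)(=O)c1ccc(C)c(C#Cc2cc(Cl)ccc2OCC(=O)O)c1` has not yet been measured. It differs from compound 1 by methylamino in place of benzyl on a sulfonyl sulfur. The sulfonyl group is retained, so the large loss seen in compound 3 is not expected to apply. What bears on the change instead is the pair compound 1 and compound 2, whose values lie within the scatter of each other although benzylsulfonyl and methylsulfonyl differ greatly in size; the substituent on the sulfonyl sulfur therefore appears tolerant to variation across these two compounds. Among the compounds with values here, no measured step covers methylsulfamoyl itself, so some uncertainty remains.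

The expected step is a 1.6-fold higher number from compound 1 to compound 4 (0.20 log units; within the scatter), i.e. no change beyond the scatter or at most a modest one. Compound 4 is estimated at 8 nM, with a range of 2.5 nM to 25 nM.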

Compound 4, inhibition constant: 10 nM
Beside the measured number, compound 4's estimate is 1.3-fold (0.10 log units) below it; the measured number falls inside the stated range.
By their numbers in this assay, from the lowest: compounds 2, 1 and 4 (each within the scatter of the next, the first and the last beyond it); then compound 3.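

In this assay methylamino in place of benzyl on the sulfonyl sulfur gives a 2.0-fold higher number from compound 1 to compound 4 (0.30 log units; within the scatter) and so shows, for this one pair, that the benzyl group and its aromatic ring can be given up without a step beyond the scatter. The earlier compounds shown here offered no comparison at this atom that differed in one place only, and here the change from benzylsulfonyl to methylsulfamoyl also brings in a nitrogen and a hydrogen-bond donor while the rest of the core of compound 1 stays the same.

From the compounds shown here alone, what remains open is whether the hydrogen on the nitrogen of methylsulfamoyl plays any part, a question that a dimethylamino group or a plain amino group on the sulfonyl sulfur would address. Also open, going by these compounds, is how far this tolerance extends, for instance to a longer chain, a morpholine ring or a carboxylic acid on the sulfonyl sulfur, and whether it carries over to the fluorine-bearing core of compound 2.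

No measurement at hand gives a reason for this result.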